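Furan-3-yl to thiophen-3-yl on a shared core

The compounds below may be only part of what the source reports. "The series", "measured", "known", "first", "only" and "open" are said of these compounds alone.

Compound 1 `OC[C@H]1O[C@@H](n2cc(Cl)c3c(-c4cccs4)ncnc32)[C@H](O)[C@@H]1O`: 13 nM
Compound 2 `OC[C@H]1O[C@@H](n2cc(Cl)c3c(-c4ccoc4)ncnc32)[C@H](O)[C@@H]1O`: 54 nM

In a functional assay on DU-145 cells (Homo sapiens), read by sulforhodamine B assay, with a stated time of 5 days (on this read-out higher numbers stand for weaker inhibition of growth and lower numbers for stronger inhibition of growth), compound 2 stands at 54 nM as the higher of the two numbers, so it shows the weaker inhibition of growth. Compound 3 `OC[C@H]1O[C@@H](n2cc(Cl)c3c(-c4ccsc4)ncnc32)[C@H](O)[C@@H]1O` differs from compound 2 by one swap on the shared core (thiophen-3-yl in place of furan-3-yl on an aromatic carbon), with thiophen-3-yl in place of furan-3-yl. Going by the values given here, the one measured step bearing on this, a 4.2-fold higher number from compound 1 to compound 2 (0.62 log units; beyond the scatter), is modest and came with furan-3-yl replacing thiophen-2-yl, so bringing back a thiophene ring is expected to lower the number by a similar or smaller amount. The expected step is a 2.5-fold lower number from compound 2 to compound 3 (0.39 log units; beyond the scatter) in this estimate. In this assay the estimate for compound 3 is 22 nM, with an expected range of 8 nM to 60 nM around it.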

Compound 3, concentration for 50% growth inhibition: 18 nM
Beside the measured number, compound 3's estimate is 1.2-fold (0.09 log units) above it; the measured number falls inside the stated range.
By their numbers in this assay, from the lowest: compounds 1 and 3 (each within the scatter of the next); then compound 2.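

In this assay the exchange of furan-3-yl for thiophen-3-yl gives a 3.0-fold lower number from compound 2 to compound 3 (0.48 log units; beyond the scatter) and so shows that the oxygen or sulfur in this five-membered ring matters at this position, even with the same ring size and the same counted donors and acceptors. Shifting the attachment point of the thiophene gives a 1.4-fold higher number from compound 1 to compound 3 (0.14 log units; within the scatter) and lies within the scatter, so thiophen-2-yl and thiophen-3-yl cannot be told apart here. No measurement at hand explains the gap between the sulfur and oxygen rings. Still open, on these data alone, is how furan-2-yl, a phenyl ring or an amine would fare at this position.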